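The compounds below may be only part of what the source reports. "The series", "measured", "known", "first", "only" and "open" are said of these compounds alone.

Of the compounds shown here, three that share one core have been tested so far in a functional assay on L1210 cells (Mus musculus) for inhibition; on this read-out higher numbers stand for weaker inhibition and lower numbers for stronger inhibition. Compound 1 (`C#CCN(Cc1ccc2nc(NCC(=O)O)nc(O)c2c1)c1ccc(C(=O)NC(CCC(=O)O)C(=O)O)cc1`) gives > 100000 nM here, which is a limit of the assay and not a number. Compound 2 (`C#CCN(Cc1ccc2nc(Oc3ccccc3)nc(O)c2c1)c1ccc(C(=O)NC(CCC(=O)O)C(=O)O)cc1`) gives > 100000 nM here, again only a limit. Among the measured compounds shown here, compound 3 (`C#CCN(Cc1ccc2nc(S)nc(O)c2c1)c1ccc(C(=O)NC(CCC(=O)O)C(=O)O)cc1`) gives 60000 nM as the only actual number of the three. The series thus shows the limit of > 100000 nM in this assay, at which 2 of the 3 values shown sit, and little else to compare against.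

Compound 4 (`C#CCN(Cc1ccc2nc(SC)nc(O)c2c1)c1ccc(C(=O)NC(CCC(=O)O)C(=O)O)cc1`) differs from compound 3 by one change (methyl in place of hydrogen on a sulfur): methyl in place of hydrogen on a sulfur. The closest evidence comes from the steps that put sulfanyl on that aromatic carbon, namely an at least 1.6-fold lower number from compound 1 to compound 3 (0.22 log units; that floor lies within the scatter) and an at least 1.6-fold lower number from compound 2 to compound 3 (0.22 log units; that floor lies within the scatter) as floors only. Neither step tests a methyl on sulfur, so no clear step is expected in this assay in either direction, and a result at the limit remains possible. The estimated step is a 1.5-fold lower number from compound 3 to compound 4 (0.18 log units; within the scatter) in this expectation. For compound 4 the estimated value is 40000 nM with an expected range from 8000 nM to 100000 nM for the coming measurement.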

Compound 4, half-maximal inhibitory concentration: 13000 nM
Beside the measured number, compound 4's estimate is 3.1-fold (0.49 log units) above it; the measured number falls inside the stated range.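

In this assay, among the compounds shown here, putting methyl on the sulfur gives a clear change at a place where the earlier compounds offered no readable comparison: a 4.6-fold lower number from compound 3 to compound 4 (0.66 log units; beyond the scatter), beyond the scatter. Against the other two groups on that aromatic carbon, methylsulfanyl gives an at least 7.6-fold lower number from compound 2 to compound 4 (0.88 log units; beyond the scatter) and an at least 7.6-fold lower number from compound 1 to compound 4 (0.88 log units; beyond the scatter), and these floors clear the scatter, whereas the floors for sulfanyl in compound 3 did not. Both steps remain floors, with no exact size, because compound 1 and compound 2 each give only a limit of the assay: the limit of > 100000 nM in this assay, at which 2 of the 4 values shown sit.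

Going by these compounds, whether an ethyl group or a longer chain on the sulfur would lower the number further stays open, since a single step on the sulfur shows no trend with chain length. On these data alone, how methoxy, with oxygen in place of the sulfur, would compare on that aromatic carbon also stays open.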